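Phenoxypyridine N-oxide analogs: a chloro substituent in the maximal electroshock model

The source may hold more compounds than are shown below. What is called first, only, known or untested is meant among the compounds shown, and "the series" means these compounds.

Compound 1 `[O-][n+]1cccc(Oc2ccccc2)c1` gives 100 mg/kg in a functional assay on the whole organism with Mus musculus as the target, in the maximal electroshock model, with a stated time of 30 min; on this read-out lower numbers stand for an effect already at smaller amounts and higher numbers for an effect only at larger amounts of compound. Among the three compounds measured it is level with compound 2 `Cc1cc(Oc2ccccc2)c[n+]([O-])c1`, which gives 100 mg/kg, and the two together hold the lowest number; compound 3 `Cc1c(Oc2ccccc2)ccc[n+]1[O-]` gives 300 mg/kg, the furthest from compound 1. The two measured steps are both additions of a methyl group: no change at the digits printed from compound 1 to compound 2 (within the scatter), whereas a 3.0-fold higher number from compound 1 to compound 3 (0.48 log units; beyond the scatter).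

Compound 4 `[O-][n+]1ccc(Cl)c(Oc2ccccc2)c1` differs from compound 1 by chloro in place of hydrogen on an aromatic carbon. Among the compounds with values here, no measured step introduces a chloro group, and no measured step touches this position, so neither methyl step bears directly on the change. What they show is that a single small substituent on the core of compound 1 has so far either left the result unchanged or raised it modestly. Compound 4 is therefore expected to lie close to compound 1, with the estimate a 1.5-fold higher number from compound 1 to compound 4 (0.18 log units; within the scatter) covering no change or a modest rise. For compound 4 a value of 150 mg/kg is expected in this assay, in the range 60 mg/kg to 400 mg/kg.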

Compound 4, minimum effective dose: > 300 mg/kg
Compound 4: no number, only a limit (the forecaster's own chance of this, stated with the estimate: 10%); middle value at least 2.0-fold (0.30 log units) from the limit.
By their numbers in this assay, from the lowest: compounds 1 and 2 (each within the scatter of the next); then compound 3.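

In this assay compound 4 gives only a limit, not a number: the limit of > 300 mg/kg in this assay, at which 1 of the 4 values shown sits.

Chloro in place of hydrogen at this position, ortho to a group of 7 heavy atoms and opposite the ring nitrogen, is a change that no earlier step touched, and it gives an at least 3.0-fold higher number from compound 1 to compound 4 (0.47 log units; beyond the scatter). The earlier steps shown here showed only what methyl does elsewhere on the core of compound 1, whereas this step shows that a single replacement at this position is enough to move the result beyond the scatter.

Going by these compounds, how far past its limit compound 4 lies stays open, so the full size of the step cannot be told. Also open, on these data alone, is whether the rise belongs to chloro itself or to any group at this position, a question that a methyl, a fluoro or an amine here would address.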